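The compounds below may be only part of what the source reports. "The series", "measured", "known", "first", "only" and "open" are said of these compounds alone.

Compound 2 `CCC[C@H]1C[C@@H](OC)C/C(C)=C\[C@@H]2C[C@@H](OC(=O)/C=C\CCc3coc(/C=C\CNC(=O)OC)n3)C[C@H](CC(=O)O1)O2` gives 0.5 nM in a functional assay on A549 cells (Homo sapiens) for antiproliferative activity, read by WST assay, with a stated time of 120 h (on this read-out higher numbers stand for weaker inhibition and lower numbers for stronger inhibition), the lowest of the three numbers recorded there. Compound 3 `CCC[C@H]1C[C@@H](OC)C/C(C)=C\[C@@H]2C[C@@H](OC(=O)/C=C(/C)CCc3coc(/C=C\CNC(=O)OC)n3)C[C@H](CC(=O)O1)O2` gives 6.3 nM in this assay, and compound 1 `CCC[C@H]1C[C@@H](OC)C/C(C)=C\[C@@H]2C[C@@H](OC(=O)CCCCc3coc(/C=C\CNC(=O)OC)n3)C[C@H](CC(=O)O1)O2` gives 110 nM, both gaps from compound 2 lying beyond the scatter, so compound 2 is the most potent of the three measured compounds.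

Compound 4 `C/C=C\c1nc(CC/C=C\C(=O)O[C@H]2C[C@@H]3CC(=O)O[C@@H](CCC)C[C@@H](OC)C/C(C)=C\[C@H](C2)O3)co1` has not yet been measured. It differs from compound 2 in one place: hydrogen in place of (methoxycarbonyl)amino on a saturated chain carbon bound to a double-bonded chain carbon. The side chain keeps its double bond but carries no hydrogen-bond donor and no hydrogen-bond acceptor where the (methoxycarbonyl)amino had stood.

Within the data shown here, no measured pair isolates this change, so the expectation rests on the weight of what leaves. A group with a hydrogen-bond donor and two acceptors is removed without replacement, and compound 4 is expected to lose ground against compound 2, with the step from compound 2 to compound 4 estimated at a 40-fold higher number from compound 2 to compound 4 (1.60 log units; beyond the scatter), beyond the scatter. Compound 4 is therefore estimated at 20 nM in this assay, within a range of 3 nM to 200 nM.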

Compound 4, half-maximal inhibitory concentration: 740 nM
For compound 4 the middle estimate is 37-fold (1.57 log units) below the measured one; measured number outside the range, above it.
By their numbers in this assay, from the lowest: compound 2; then compound 3; then compound 1; then compound 4.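

Taking away the (methoxycarbonyl)amino from the saturated chain carbon bound to a double-bonded chain carbon produces a 1500-fold higher number from compound 2 to compound 4 (3.17 log units; beyond the scatter) in this assay, a large loss. Compounds 1, 2 and 3 all carry this group, so they could not show how much depended on it; this step shows that the potency of compound 2 depends heavily on the group, even though the side-chain double bond remains. No available evidence accounts for the size of this loss.

The compounds shown leave open whether an amine, a hydroxyl or an acetamide on the same carbon would recover the potency, and which part of the (methoxycarbonyl)amino matters most. They also leave open whether the same removal would cost as much in compound 1 or compound 3.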